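The source may report more compounds than this note shows. Statements on the series, on what has been measured and on what is new or still open speak of the compounds shown alone.

Compound 3, with the structure `CC(C)[C@@H](C(=O)Nc1ccc(C(=O)Nc2ccc(F)cc2N)cc1)c1ccccc1`, is the starting point. In an assay on isolated protein for inhibition of histone deacetylase 8 (Homo sapiens), read by fluorescence, tested at 1 uM (on this read-out higher numbers stand for more inhibition at the one concentration tested (going by the name of the read-out) and lower numbers for less inhibition), compound 3 gives 6%. That puts compound 3 at the top of the three numbers measured, yet it is not separated from either of the other two beyond the usual scatter. Compound 1, with the structure `CC(C)(C(=O)Nc1ccc(C(=O)Nc2ccc(F)cc2N)cc1)c1ccccc1`, gives 0% in this assay, and compound 2, with the structure `CC(C)[C@@H](C(=O)Nc1ccc(C(=O)Nc2ccc(C(F)(F)F)cc2N)cc1)c1ccccc1`, gives 0%. The two single changes that lead to compound 3 are small: a number 6 percentage points higher from compound 1 to compound 3 (within the scatter), and a number 6 percentage points higher from compound 2 to compound 3 (within the scatter).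

Compound 4, with the structure `Nc1cc(F)ccc1NC(=O)c1ccc(NC(=O)C2CC2c2ccccc2)cc1`, differs from compound 3 in one place: 2-phenylcyclopropyl in place of 2-methyl-1-phenylpropyl on a carbonyl carbon. This change sits on the same carbonyl carbon as the change from compound 1 to compound 3, and that step stayed within the scatter. Within the data shown here, nothing measured so far shows a group on this carbonyl carbon moving the read-out by more than the scatter. For compound 4 the expected step is therefore a number 1 percentage points lower from compound 3 to compound 4 (within the scatter), which is essentially no change. Compound 4 is estimated to give 5% in this assay, within a range from 0% to 15%.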

Compound 4, a percentage reported as inhibition, at one concentration (the size of the read-out at that concentration, not a potency): 14%
Compound 4: middle estimate off by 9 percentage points, on the low side, and the stated range covers the measured number.
By their numbers in this assay, from the lowest: compounds 1, 2, 3 and 4 (each within the scatter of the next, the first and the last beyond it).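

Among these compounds, putting 2-phenylcyclopropyl in place of 1-methyl-1-phenylethyl on the carbonyl carbon gives a number 14 percentage points higher from compound 1 to compound 4 (beyond the scatter) in this assay and is the first step at this place to clear the usual scatter. Measured against 2-methyl-1-phenylpropyl, the same group gives only a number 8 percentage points higher from compound 3 to compound 4 (within the scatter) so the two compounds at the top of this short series cannot be told apart. Nothing measured here accounts for the difference between these groups.

On these data alone, it remains open whether the three-membered ring matters or only the phenyl ring it carries, and a plain cyclopropyl or a 2-phenylethyl chain on this carbonyl carbon would help separate the two. Also open, as far as these compounds go, is whether the number in this assay for a compound carrying 2-phenylcyclopropyl would be higher, lower or level with trifluoromethyl in place of fluoro on the aromatic carbon.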